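This account rests on a few compounds, and the source may have more. Where it says the series, first, only, none or still open, it means among the compounds named here.

Measured so far:
Compound 1 `N#CCCn1nc(-c2ccc(OCc3cccc(Cl)c3)cc2)oc1=O` in an assay for inhibition of Amine oxidase [flavin-containing] A (Rattus norvegicus) (a higher number here means a weaker inhibitor, a lower number a stronger inhibitor), gives 7400 nM.
Compound 2 `N#CCCn1nc(-c2ccc(OCc3ccc([N+](=O)[O-])cc3)cc2)oc1=S` in this assay gives 2600 nM.
Compound 3 `N#CCCN1N=C(c2ccc(OCc3ccccc3)cc2)OCC1=O` in this assay gives 160000 nM.

Compound 3 stands at the highest number of the three, well beyond the scatter from compound 1 and further still from compound 2, so it is the weakest inhibitor shown. Compound 4 `Cc1cccc(COc2ccc(C3=NN(CCC#N)C(=O)CO3)cc2)c1` differs from compound 3 by a single change, methyl in place of hydrogen on an aromatic carbon. Among the measured compounds shown here, no measured pair shows a comparable step, so the expectation rests on the size of the change alone. The step from compound 3 to compound 4 is expected to be small, likely within the scatter, with a slight lean towards a lower number, estimated as a 1.6-fold lower number from compound 3 to compound 4 (0.20 log units; within the scatter). Compound 4 is therefore expected at 100000 nM, within 40000 nM to 300000 nM.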

Compound 4, half-maximal inhibitory concentration: 40000 nM
Compound 4: the middle estimate sits 2.5-fold (0.40 log units) above what was measured; measured number inside the range.
By their numbers in this assay, from the lowest: compound 2; then compound 1; then compound 4; then compound 3.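

Benzyl to 3-methylbenzyl gives a 4.0-fold lower number from compound 3 to compound 4 (0.60 log units; beyond the scatter) in this assay and is the first single-place step in the series. It shows that this aromatic ring responds to one added methyl, a step beyond the scatter. Nothing available explains the size of this step.

As far as these compounds go, whether an ethyl or a methoxy group on the same aromatic carbon would go further remains open. Also open, from the compounds shown here alone, is whether the same methyl gives a similar step on the cores of compound 1 and compound 2.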